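A few compounds are considered here, and "the series" means these few. Any claim that something is new, unique, unknown or untested is made for them only; others in the source may bear on it.

Compound 1 `O=C1C(Nc2ccc(C(F)(F)F)cc2)=CC(=O)c2c1nc1n2[C@H]2OC[C@@H](O)[C@H]2OC1` gives 8920 nM in a functional assay on HeLa cells (Homo sapiens) for inhibition, read by sulforhodamine B assay; on this read-out lower numbers stand for stronger inhibition and higher numbers for weaker inhibition.
Compound 2 `COc1ccc(NC2=CC(=O)c3c(nc4n3[C@H]3OC[C@@H](O)[C@H]3OC4)C2=O)cc1` gives only a limit of this assay, > 8000 nM.
Compound 3 `O=C1C=C(Nc2ccc(C(F)(F)F)cc2)C(=O)c2c1nc1n2[C@H]2OC[C@@H](O)[C@H]2OC1` also gives only a limit, > 8000 nM.

Compound 1 and compound 2 share a core; their one difference is methoxy in place of trifluoromethyl on an aromatic carbon and it made a step that the limit leaves unreadable from compound 1 to compound 2. Compound 3 has the same atoms as compound 1, joined differently; the difference between the two cores is not broken down here. Compound 4 `COc1ccc(NC2=CC(=O)c3nc4n(c3C2=O)[C@H]2OC[C@@H](O)[C@H]2OC4)cc1` is not yet measured and stands to compound 3 as compound 2 stands to compound 1: the same change, (methoxy in place of trifluoromethyl on an aromatic carbon). Compound 3 already sits at the limit of > 8000 nM in this assay, at which 2 of the 3 values shown sit, so the step from compound 3 to compound 4 is expected to be unreadable in the same way, a step that the limit leaves unreadable from compound 3 to compound 4. Compound 4 is estimated at 15000 nM, most likely reported as a limit again, between 5000 nM and 50000 nM.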

Compound 4, half-maximal inhibitory concentration: 4780 nM
Estimate against measurement, compound 4: 3.1-fold (0.50 log units) above; measured number outside the range, below it.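

In this assay, methoxy in place of trifluoromethyl gave an at least 1.6-fold lower number from compound 3 to compound 4 (0.22 log units; that floor lies within the scatter), so on this core the change shows no shift that can be told from the scatter, although the printed size is only a floor and the true step could be larger. The result therefore does not show that the change lowers the number on this core, let alone on the core of compound 1. Whether the change carries from one core to the other stays unsettled, because neither step can be read to its full size: the limit of > 8000 nM in this assay, at which 2 of the 4 values shown sit.

The compounds shown leave open how an amine or a carboxylic acid in place of methoxy would read in this assay. On these data alone, it also remains open whether a longer chain, such as ethoxy, would follow methoxy on either core.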